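Replacing the nitro group of compound 2

The source may hold more compounds than are shown below. What is called first, only, known or untested is meant among the compounds shown, and "the series" means these compounds.

In a functional assay on B16 cells (Mus musculus) for cytotoxicity, read by MTT assay (a higher number here means a weaker inhibitor, a lower number a stronger inhibitor), compound 1 `COc1cc(/C(=C\c2cccc([N+](=O)[O-])c2)C(C)=O)cc(OC)c1OC` gives 3800 nM. Compound 2 `COc1ccc(/C=C(/C(C)=O)c2cc(OC)c(OC)c(OC)c2)cc1[N+](=O)[O-]` gives 3800 nM. Among the measured compounds shown here, the one measured single-place step is no change at the digits printed from compound 1 to compound 2 (within the scatter), so compound 2 stands level with the only other compound that has a numeric reading. Compound 3 `COc1cc(OC)c(/C=C(/C(C)=O)c2cc(OC)c(OC)c(OC)c2)c(OC)c1` is reported only as a limit, > 100000 nM.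

Compound 4 `COc1ccc(/C=C(/C(C)=O)c2cc(OC)c(OC)c(OC)c2)cc1O[Si](C)(C)C(C)(C)C` comes from compound 2 by a group of 8 heavy atoms (6 carbon, 1 oxygen, 1 silicon; no ring) in place of a group of 3 heavy atoms (1 nitrogen, 2 oxygen; no ring), on an aromatic carbon. The site is ortho to a methoxy group and meta to a large group. No measured step replaces a nitro group, so the step shown above bears only indirectly and gives no size for this change. Compound 3, which also has no nitro group, marks (the limit of > 100000 nM in this assay, at which 1 of the 3 values shown sits), which leaves room for a much weaker reading. A moderate move toward weaker inhibition in this assay is therefore expected, with wide uncertainty. The expected change is a 2.6-fold higher number from compound 2 to compound 4 (0.42 log units; beyond the scatter). For compound 4 the estimate is 10000 nM, with an expected range of 1500 nM to 60000 nM.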

Compound 4, half-maximal inhibitory concentration: 5100 nM
The estimate for compound 4 lay 2.0-fold (0.29 log units) above the measured number; low and high end bracket the measured number.
By their numbers in this assay, from the lowest: compounds 1, 2 and 4 (each within the scatter of the next). At a limit, above all of these: compound 3.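

In this assay, the aromatic carbon that carries the nitro group in compound 2 also takes the group of 8 heavy atoms (6 carbon, 1 oxygen, 1 silicon), and the step is a 1.3-fold higher number from compound 2 to compound 4 (0.13 log units; within the scatter). The nitro group, with its 2 hydrogen-bond acceptors, is therefore not required at this site for this reading, and the count of heavy atoms there can rise from 3 to 8 with no change beyond the scatter. Nothing in the data at hand gives a reason for this result.

From the compounds shown here alone, how a free hydroxyl, an amine or a carboxylic acid would read at this site remains open. Compound 3 is reported only as a limit, > 100000 nM, and it differs from compound 2 in more than one place, so it does not settle this position.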